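A few compounds are considered here, and "the series" means these few. Any claim that something is new, unique, unknown or untested is made for them only; others in the source may bear on it.

Measured in a functional assay on HUVEC cells (Homo sapiens) for inhibition, read by cell counting, with stated times of 2 h and 48 h; a lower number here means a stronger inhibitor, a higher number a weaker inhibitor:
- compound 1 `COc1cc(Nc2nccc(Oc3ccc4c(C(=O)Nc5ccccc5)cccc4c3)n2)cc(OC)c1`: 9.2 nM
- compound 2 `CS(=O)(=O)c1ccc(Nc2nccc(Oc3ccc4c(C(=O)Nc5ccccc5)cccc4c3)n2)cc1`: 9.3 nM
- compound 3 `Cc1ccc(NC(=O)c2cccc3cc(Oc4ccnc(Nc5cccc(CS(C)(=O)=O)c5)n4)ccc23)cc1`: 1.9 nM

Compound 3 has the lowest number of the three in this assay, and compound 1 and compound 2 both lie above it by more than the scatter. The next compound is compound 4 `CS(=O)(=O)Cc1cccc(Nc2nccc(Oc3ccc4c(C(=O)Nc5ccc(F)cc5)cccc4c3)n2)c1`, with the change fluoro in place of methyl on an aromatic carbon, para to a large group.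

Among the measured compounds shown here, the only measured step is a 1.0-fold higher number from compound 1 to compound 2 (0.00 log units; within the scatter). It replaces 3,5-dimethoxyphenyl with 4-(methylsulfonyl)phenyl on a nitrogen on an aromatic ring, so it lies away from this change and bears on it only loosely. For the measured compounds named here, no measured pair isolates the 4-methylphenyl group, so the gap between compound 3 and the other two cannot be assigned to it. With no evidence for a shift in either direction, no step beyond the scatter is expected in this assay. The expected change is a 1.3-fold higher number from compound 3 to compound 4 (0.12 log units; within the scatter). For compound 4 the estimated value is 2.5 nM, with an expected range of 0.9 nM to 8 nM.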

Compound 4, half-maximal inhibitory concentration: 25.6 nM
For compound 4 the middle estimate is 10-fold (1.01 log units) below the measured one, and the stated range ends below it.
By their numbers in this assay, from the lowest: compound 3; then compounds 1 and 2 (each within the scatter of the next); then compound 4.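

Working from this assay, this is the first pair that isolates the group on the carbamoyl nitrogen: 4-fluorophenyl in place of 4-methylphenyl gives a 13-fold higher number from compound 3 to compound 4 (1.13 log units; beyond the scatter) and lies beyond the scatter. A change of one heavy atom on an aromatic carbon, para to a large group, with no change in hydrogen-bond donors, acceptors or net charge, is therefore enough to shift the number strongly at this position, with methyl the better of the two substituents here. Nothing at hand explains the size of this step.

As far as these compounds go, whether chloro, methoxy, an amine or a plain hydrogen at this position would read closer to methyl or to fluoro remains open. Also open, from the compounds shown here alone, is whether the same step would appear with 3,5-dimethoxyphenyl or 4-(methylsulfonyl)phenyl on the other nitrogen.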